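The source may report more compounds than this note shows. Statements on the series, on what has been measured and on what is new or still open speak of the compounds shown alone.

The series rests on one shared core, carried by compound 1 `CC[C@@H](C)[C@H](NC(=O)c1ccc(C(CC)(CC)c2ccc(OCC(O)C(C)(C)C)c(C)c2)n1CC)C(=O)OC`, compound 2 `CCn1c(C(=O)NCC(OC)OC)ccc1C(CC)(CC)c1ccc(OCC(O)C(C)(C)C)c(C)c1` and compound 3 `C=CCN(C)C(=O)c1ccc(C(CC)(CC)c2ccc(OCC(O)C(C)(C)C)c(C)c2)n1CC`, and the three differ only in what the carbonyl carbon bears. In an assay on HL-60 cells for agonist activity at vitamin D3 receptor (Homo sapiens), read by microscopy, with a stated time of 96 h (a higher number here means that more compound is needed for the effect, a lower number that less compound is needed), compound 1 gives 26 nM, compound 2 gives 150 nM and compound 3 gives 3950 nM. Compound 3 thus stands at the highest number of the three: a 150-fold higher number from compound 1 to compound 3 (2.18 log units; beyond the scatter) and a 26-fold higher number from compound 2 to compound 3 (1.42 log units; beyond the scatter), while the two lower-numbered compounds are separated by less, a 5.8-fold higher number from compound 1 to compound 2 (0.76 log units; beyond the scatter). Compound 4 `C#CCCOC(=O)c1ccc(C(CC)(CC)c2ccc(OCC(O)C(C)(C)C)c(C)c2)n1CC` continues from compound 3 with (but-3-yn-1-yl)oxy in place of allyl(methyl)amino on a carbonyl carbon, a triple bond outside aromatic rings replacing a double bond outside aromatic rings. For the measured compounds named here, no measured step exchanges an amide-type nitrogen for an ester oxygen on this carbonyl carbon, so none bears on the change directly; the three measured steps show only that alterations at this carbonyl carbon shift the number by large amounts. With compound 3 already at the highest number of the set, a fall seems somewhat more likely than a further rise, but the direction is not settled and the range must stay wide. The estimate for compound 4 in this assay is 1500 nM, with a range from 250 nM to 9000 nM. This expectation for compound 4 amounts to a 2.6-fold lower number from compound 3 to compound 4 (0.42 log units; beyond the scatter).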

Compound 4, half-maximal effective concentration: 1030 nM
Estimate against measurement, compound 4: 1.5-fold (0.16 log units) above; the range from low to high includes it.
By their numbers in this assay, from the lowest: compound 1; then compound 2; then compound 4; then compound 3.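

In this assay, the ester of compound 4 gives [ a 3.8-fold lower number from compound 3 to compound 4 (0.58 log units; beyond the scatter) ], so a carbonyl carbon bearing (but-3-yn-1-yl)oxy instead of allyl(methyl)amino stays well short of the two lowest numbers in the set, although the step is smaller than either of those from compound 1 or compound 2 to compound 3. The gap to the compounds with an amide hydrogen remains beyond the scatter, with [ a 6.9-fold higher number from compound 2 to compound 4 (0.84 log units; beyond the scatter) ] and [ a 40-fold higher number from compound 1 to compound 4 (1.60 log units; beyond the scatter) ], and among these four compounds the two that carry that hydrogen hold the two lowest numbers, while compound 3 and compound 4, which lack it, hold the two highest. Nothing available accounts for these shifts, and the step from compound 3 to compound 4 changes the oxygen for the nitrogen and the triple bond for the double bond together, so its size cannot be divided between them.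

An allyl ester, or a but-3-yn-1-yl group on an amide nitrogen, would separate those two changes. A free carboxylic acid or a plain primary amide on this carbonyl carbon would show how far the number depends on the attached chain at all.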